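The compounds below may be only part of what the source reports. "The series", "measured", "known", "first", "only" and "open" are said of these compounds alone.

Series notes. Compound 1 `O=C(O)C1CCN(c2ccccc2Cl)C1` carries the shared core with a single chloro on the aromatic ring. Among the compounds with values here, in an assay on cells for inhibition of Palmitoleoyl-protein carboxylesterase NOTUM variant C330S (Homo sapiens), read by fluorescence, with a stated time of 40 min (on this read-out higher numbers stand for weaker inhibition and lower numbers for stronger inhibition), compound 1 gives 19000 nM, the highest of the two numbers measured so far. Compound 2 `O=C(O)C1CCN(c2cccc(Cl)c2Cl)C1` in this assay gives 8000 nM; the step of a 2.4-fold lower number from compound 1 to compound 2 (0.38 log units; beyond the scatter) is the nearest comparison available for compound 1 and is the only one beyond the scatter in this small set.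

Compound 3 `O=C(O)C1CCN(c2c(Cl)cccc2Cl)C1` is not yet measured. Relative to compound 1 it differs by chloro in place of hydrogen on an aromatic carbon, on an aromatic carbon ortho to a group of 8 heavy atoms and meta to a chloro group. Within the data shown here, the one measured step of the same kind, a 2.4-fold lower number from compound 1 to compound 2 (0.38 log units; beyond the scatter), was a modest move to a lower number. Among the measured compounds shown here, only a single such step is known, so the expectation rests on it alone. A modest step down of similar size is therefore expected, a 2.1-fold lower number from compound 1 to compound 3 (0.32 log units; beyond the scatter). Compound 3 is estimated at 9000 nM, in the range 3500 nM to 25000 nM.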

Compound 3, half-maximal inhibitory concentration: 26000 nM
Beside the measured number, compound 3's estimate is 2.9-fold (0.46 log units) below it; the whole stated range lies below it.
By their numbers in this assay, from the lowest: compound 2; then compounds 1 and 3 (each within the scatter of the next).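

In this assay, chloro in place of hydrogen on an aromatic carbon ortho to a group of 8 heavy atoms and meta to a chloro group gives a 1.4-fold higher number from compound 1 to compound 3 (0.14 log units; within the scatter), so at this position the exchange does not move the read-out beyond the scatter. The same kind of exchange at the other place on the ring gave a 2.4-fold lower number from compound 1 to compound 2 (0.38 log units; beyond the scatter), so among these compounds the step depends on where the second chloro sits, not merely on its presence. Nothing at hand explains why the two places differ.

As far as these compounds go, it remains open whether a fluoro or a methoxy at this position would behave as chloro does here. Also open, from the compounds shown here alone, is how either place would respond with a primary amide in place of the carboxylic acid.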